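Swapping a Piperidin-2-yl Group for an Open-Chain Amine

The compounds below may be only part of what the source reports. "The series", "measured", "known", "first", "only" and "open" are said of these compounds alone.

Three compounds share one core and differ only in the amine that ends a side chain on the ring oxygen. Compound 1 `CC(C)=CCc1cc(C(=O)Nc2cc3ccc(OCCC4CCCCN4)c(C)c3oc2=O)ccc1O` carries a piperidin-2-yl group there, and in a functional assay on SK-BR-3 cells (Homo sapiens) for antiproliferative activity (on this read-out higher numbers stand for weaker inhibition and lower numbers for stronger inhibition), compound 1 gives 640 nM. Compound 2 `CCCNCCCOc1ccc2cc(NC(=O)c3ccc(O)c(CC=C(C)C)c3)c(=O)oc2c1C` carries a (propylamino)methyl group instead, and compound 2 gives 990 nM. Compound 3 `CC(C)=CCc1cc(C(=O)Nc2cc3ccc(OCCCN(C)C(C)C)c(C)c3oc2=O)ccc1O` carries an (isopropyl(methyl)amino)methyl group, and compound 3 gives 570 nM. On these three numbers compound 1 sits second highest, with compound 3 nearest and compound 2 furthest, and every pair lies within the scatter.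

Compound 4 `CC(C)=CCc1cc(C(=O)Nc2cc3ccc(OCCCN(C)C(C)(C)C)c(C)c3oc2=O)ccc1O` has not yet been measured. Its change from compound 1 is (methyl(tert-butyl)amino)methyl in place of piperidin-2-yl on a saturated chain carbon, two bonds along the chain from an oxygen on an aromatic ring. Among the measured compounds shown here, two measured steps bear on it: a 1.1-fold lower number from compound 1 to compound 3 (0.05 log units; within the scatter), which also replaces the ring by an open-chain amine, and a 1.5-fold higher number from compound 1 to compound 2 (0.19 log units; within the scatter). Neither step left the scatter, and compound 4 differs from compound 3 only in one more carbon on the amine, so no step beyond the scatter is expected in this assay. The step from compound 1 to compound 4 is estimated as a 1.0-fold lower number from compound 1 to compound 4 (0.01 log units; within the scatter). Compound 4 is therefore expected to give about 620 nM, within a range from 300 nM to 1300 nM.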

Compound 4, half-maximal inhibitory concentration: 880 nM
For compound 4 the middle estimate is 1.4-fold (0.15 log units) below the measured one; measured number inside the range.
By their numbers in this assay, from the lowest: compounds 3, 1, 4 and 2 (each within the scatter of the next).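

In this assay, compound 4 brings a tert-butyl group onto the amine, and the one extra methyl, in place of hydrogen on a saturated chain carbon bound to an amine nitrogen and two saturated chain carbons, gives a 1.5-fold higher number from compound 3 to compound 4 (0.19 log units; within the scatter), which stays within the scatter. Replacing piperidin-2-yl with (methyl(tert-butyl)amino)methyl gives a 1.4-fold higher number from compound 1 to compound 4 (0.14 log units; within the scatter), and changing propylamino to methyl(tert-butyl)amino gives a 1.1-fold lower number from compound 2 to compound 4 (0.05 log units; within the scatter), both also within the scatter, so this larger open-chain amine, with no ring and 0 hydrogen-bond donors in the group, still leaves all four compounds within the scatter of one another. Nothing available here accounts for the small differences among these numbers.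

On these data alone, what a morpholine or a carboxylic acid would do at the end of this chain, or what a longer chain would do, remains open. Also open, as far as these compounds go, is whether any change at this position can move the number in this assay beyond the scatter.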